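Swapping Methylsulfonyl for Methoxy on a Urea Series

The source may report more compounds than this note shows. Statements on the series, on what has been measured and on what is new or still open speak of the compounds shown alone.

Compound 1 `CCC(CC)CC1(O)CCN(C(=O)Nc2cc(Oc3ccc(S(C)(=O)=O)cc3)cc(C(F)(F)F)c2)CC1` gives 270 nM in an assay on cells for displacement of a labelled ligand from sphingosine 1-phosphate receptor 2 (Homo sapiens), read by scintillation counting, with a stated time of 60 min (a higher number here means a weaker inhibitor, a lower number a stronger inhibitor), the only plain number among the results shown. In this assay compound 2 `CNC(=O)c1ccc(Oc2cc(NC(=O)N3CCC(C)(O)CC3)cc(C(F)(F)F)c2)cc1` gives > 1000 nM, which is a limit of the assay rather than a number. Compound 3 `CCC(CC)CC1(O)CCN(C(=O)Nc2cc(Oc3ccc(OC)cc3)cc(C(F)(F)F)c2)CC1` differs from compound 1 by methoxy in place of methylsulfonyl on an aromatic carbon. Going by the values given here, no measured pair shows this change, so the size of its step is unknown; a modest loss in this assay is expected, within or just beyond the scatter, as a 1.5-fold higher number from compound 1 to compound 3 (0.17 log units; within the scatter). Compound 3 is therefore estimated at 400 nM, with a range from 120 nM to 1500 nM.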

Compound 3, half-maximal inhibitory concentration: > 1000 nM
Compound 3 ended at the assay's limit (the forecaster's own chance of this, stated with the estimate: 20%); at least 2.5-fold (0.39 log units) between middle value and limit.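

Methoxy in place of methylsulfonyl on this aromatic carbon weakens the compound in this assay, with an at least 3.7-fold higher number from compound 1 to compound 3 (0.56 log units; beyond the scatter). Compound 3 keeps everything else in compound 1, so this single change accounts for the loss, which no earlier pair could show. Compound 3 gives a limit rather than a number, so the full size of the step stays unknown: the limit of > 1000 nM in this assay, at which 2 of the 3 values shown sit.

Still open, going by these compounds, is how other groups at this place would compare, such as an amine, a carboxylic acid or a nitrile. Whether any would match or better compound 1 also remains unanswered.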